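Ester to Ketone on a Shared Cyclohexenyl Sulfone Core

This account rests on a few compounds, and the source may have more. Where it says the series, first, only, none or still open, it means among the compounds named here.

Measured compounds:
compound 1, `CCOC(=O)C1=CCCCC1S(=O)(=O)Cc1ccc(Cl)c(Cl)c1`, 53 nM
compound 2, `COC(=O)C1=CCCCC1S(=O)(=O)Cc1ccc(F)cc1Cl`, 99 nM

Two compounds were tested in a functional assay on RAW264.7 cells (Mus musculus), read by fluorescence; on this read-out higher numbers stand for weaker inhibition and lower numbers for stronger inhibition. Compound 1 `CCOC(=O)C1=CCCCC1S(=O)(=O)Cc1ccc(Cl)c(Cl)c1` gives 53 nM, and compound 2 `COC(=O)C1=CCCCC1S(=O)(=O)Cc1ccc(F)cc1Cl` gives 99 nM. On these two numbers compound 2 stands at the upper end, but its gap to compound 1 falls within the usual scatter of repeated measurements, so the two cannot be told apart on this evidence. For the measured compounds named here, no step between compounds that differ in one place is available.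

Compound 3 `CCC(=O)C1=CCCCC1S(=O)(=O)Cc1ccc(F)cc1Cl` has not yet been measured in this assay. It differs from compound 2 by ethyl in place of methoxy on a carbonyl carbon. Going by the values given here, nothing among the measured compounds speaks to this change, so the expected step (a 1.2-fold higher number from compound 2 to compound 3 (0.08 log units; within the scatter)) is none beyond the scatter. Compound 3 is therefore estimated at 120 nM, with a range from 40 nM to 400 nM.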

Compound 3, half-maximal inhibitory concentration: 64 nM
Estimate against measurement, compound 3: 1.9-fold (0.27 log units) above, within the range that was stated.
By their numbers in this assay, from the lowest: compounds 1, 3 and 2 (each within the scatter of the next).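

In this assay, replacing methoxy with ethyl on a carbonyl carbon, which turns methoxycarbonyl into propanoyl, gives a 1.5-fold lower number from compound 2 to compound 3 (0.19 log units; within the scatter) on the otherwise unchanged structure. For the compounds shown here, this is the first comparison here between compounds that differ in one place, and it shows that at this position the ester and the ketone cannot be told apart in this assay. No measurement shown accounts for this result.

The compounds shown leave open whether a longer chain, an amine or a carboxylic acid in place of the ethyl would stay within the scatter of compound 3. They also leave open whether the same exchange of methoxycarbonyl for propanoyl would give a comparable step on the core of compound 1.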